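The compounds below may be only part of what the source reports. "The series", "measured", "known", "first", "only" and "open" are said of these compounds alone.

Compound 1 `CCCCCCCCCCc1ccc(CCC(N)(CO)CO)cc1`, compound 2 `CCCCCCCCCCCc1ccc(CCC(N)(CO)CO)cc1` and compound 3 `CCCCCCCCCCCCc1ccc(CCC(N)(CO)CO)cc1` share one core and differ from one another only along the saturated chain attached to the aromatic ring. In a functional assay on the whole organism with Rattus norvegicus as the target (on this read-out lower numbers stand for an effect already at smaller amounts and higher numbers for an effect only at larger amounts of compound), compound 1 gives 0.1 mg/kg. In this assay compound 2 gives 0.1 mg/kg. In this assay compound 3 gives 0.1 mg/kg. Compound 3 therefore stands level with compound 1 and compound 2 at the digits shown: the step of no change at the digits printed from compound 1 to compound 3 (within the scatter) and the step of no change at the digits printed from compound 2 to compound 3 (within the scatter) both lie within the scatter, as does the step of no change at the digits printed from compound 1 to compound 2 (within the scatter).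

Compound 4 `CCCCCCCCCCCCCCc1ccc(CCC(N)(CO)CO)cc1` has not yet been measured in this assay. It differs from compound 3 by ethyl in place of hydrogen on a saturated chain carbon, ten or more bonds along the chain from an aromatic carbon. All three measured steps bear directly on this change, since each of them also adds a methyl or an ethyl in place of hydrogen on a saturated chain carbon, ten or more bonds along the chain from an aromatic carbon, and none of them moved the read-out beyond the scatter. Among the compounds with values here, on that basis the step of no change at the digits printed from compound 3 to compound 4 (within the scatter) is expected to show no change beyond the scatter, in neither direction, though this rests on only three compounds. For compound 4 in this assay the estimate is 0.1 mg/kg, with a range from 0.05 mg/kg to 0.2 mg/kg.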

Compound 4, dose for 50% inhibition: 1 mg/kg
Compound 4: the middle estimate sits 10-fold (1.00 log units) below what was measured, and the stated range ends below it.
By their numbers in this assay, from the lowest: compounds 1, 2 and 3 (each within the scatter of the next); then compound 4.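

In this assay, within the data shown here, this place on the chain turns out not to be open without limit: ethyl in place of hydrogen on a saturated chain carbon, ten or more bonds along the chain from an aromatic carbon, gives the first step here to go beyond the scatter (a 10-fold higher number from compound 3 to compound 4 (1.00 log units; beyond the scatter)), and propyl (a 10-fold higher number from compound 2 to compound 4 (1.00 log units; beyond the scatter)) and butyl (a 10-fold higher number from compound 1 to compound 4 (1.00 log units; beyond the scatter)) in the same place arrive at compound 4 as well. Among these compounds, the same ethyl change had left the read-out within the scatter when made on the shorter chain (no change at the digits printed from compound 1 to compound 3 (within the scatter)), so its size at this place depends on the chain that carries it, and the earlier compounds could not show that. The compounds give no measurement that accounts for this rise, so it stands here without an explanation.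

As far as these compounds go, it remains open whether methyl alone on compound 3 would already move the read-out, or whether the rise needs the full ethyl, and whether a longer chain than that of compound 4 would raise the number further. Equally open, from the compounds shown here alone, is how a carboxylic acid or an amine at the end of the chain would read out in this assay.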